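Aryl sulfonamide series: from compound 3 to compound 4

A few compounds are considered here, and "the series" means these few. Any claim that something is new, unique, unknown or untested is made for them only; others in the source may bear on it.

Compound 1 `C=Cc1ccc(S(=O)(=O)Nc2ccc3oc(-c4ccccc4)nc3c2)cc1` gives in an assay on isolated protein for inhibition of malate dehydrogenase, mitochondrial (Sus scrofa), with stated times of 45 min and 30 min (on this read-out higher numbers stand for weaker inhibition and lower numbers for stronger inhibition), only a limit, > 63000 nM.
Compound 2 `O=S(=O)(Nc1ccc2oc(-c3ccccc3)nc2c1)c1cccc(F)c1` gives in this assay only a limit, > 63000 nM.
Compound 3 `O=S(=O)(Nc1ccc2oc(-c3ccccc3)nc2c1)c1ccccc1F` gives in this assay only a limit, > 63000 nM.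

Compound 3 thus stands at a limit of this assay, and the two further values shown are limits as well (the limit of > 63000 nM in this assay, at which 3 of the 3 values shown sit). The steps a step that the two limits leave unreadable from compound 1 to compound 2, a step that the two limits leave unreadable from compound 1 to compound 3 and a step that the two limits leave unreadable from compound 2 to compound 3 therefore carry no readable size, in either direction.

Compound 4 `CCc1ccc(S(=O)(=O)Nc2ccc3oc(-c4ccccc4)nc3c2)cc1` differs from compound 3 by 4-ethylphenyl in place of 2-fluorophenyl on a sulfonyl sulfur. The measured steps that bear on this change are the three above, each an exchange of the aryl group on the sulfonyl sulfur, and each left unreadable by the limits. For the measured compounds named here, from them no size of step and no direction can be taken for compound 4 in this assay, and the most that is expected is a step that the limit leaves unreadable from compound 3 to compound 4, with a high chance that only a limit is reported again. Compound 4 is expected to give about 80000 nM, in the range 20000 nM to 300000 nM.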

Compound 4, half-maximal inhibitory concentration: > 63000 nM
Compound 4 gave a limit, no number (the forecaster's own chance of this, stated with the estimate: 80%); the middle value does not contradict the limit.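

Compound 4 gives only a limit in this assay, so no step between it and compound 1, compound 2 or compound 3 can be read: the limit of > 63000 nM in this assay, at which 4 of the 4 values shown sit.

The compounds shown leave open whether any of these aryl groups on the sulfonyl sulfur gives a measurable inhibition, and how large any step between them would be.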